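A few compounds are considered here, and "the series" means these few. Any claim that something is new, unique, unknown or untested is made for them only; others in the source may bear on it.

In a functional assay on HCT-116 cells (Homo sapiens) for cytotoxicity, read by scintillation counting and thymidine incorporation, with a stated time of 72 h (a higher number here means a weaker inhibitor, a lower number a stronger inhibitor), compound 1 (`CC=C(c1cc(OC)cc(OC)c1)c1ccc(OC)c(OC)c1`) gives 480 nM as its reading. Compound 2 (`COc1cc(OC)cc(C(=CC(C)=O)c2ccc(OC)c(OC)c2)c1`) has only a limit of > 10000 nM in this assay and no exact number. Compound 3 (`COC=C(c1cc(OC)cc(OC)c1)c1ccc(OC)c(OC)c1`) carries methoxy in place of acetyl on a double-bonded chain carbon bound to a double-bonded chain carbon. For the measured compounds named here, the one measured step that bears on this is large and brought that acetyl in for a methyl: an at least 20-fold higher number from compound 1 to compound 2 (1.31 log units; beyond the scatter) is what it showed. Going by the values given here, no measured step covers methoxy itself, so only a partial return towards compound 1 is expected. The expected change is a large one towards a lower number (an at least 6.6-fold lower number from compound 2 to compound 3 (0.82 log units; beyond the scatter)) in this assay overall. Compound 3 is estimated at 1500 nM with an expected range of 250 nM to 9000 nM in this test.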

Compound 3, half-maximal inhibitory concentration: > 10000 nM
Compound 3: no number, only a limit; the forecaster's own chance of this, stated with the estimate: 15%; middle value at least 6.6-fold (0.82 log units) from the limit.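

In this assay, putting methoxy where methyl stood gives an at least 20-fold higher number from compound 1 to compound 3 (1.31 log units; beyond the scatter). So a second group, smaller than acetyl, also loses the reading that methyl gives, and among the three groups shown only methyl gives an exact number. Compound 2 and compound 3 each have only a limit, so the step between them cannot be read: the limit of > 10000 nM in this assay, at which 2 of the 3 values shown sit.

On these data alone, how far past that limit either compound lies stays open. Also open, as far as these compounds go, is whether an ethyl group or an amine at this place would keep an exact reading.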